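Pentyl to allyl on the acetophenone series, nitrile-linked ethers

A few compounds are considered here, and "the series" means these few. Any claim that something is new, unique, unknown or untested is made for them only; others in the source may bear on it.

Measured so far:
compound 1, `CCCCCc1cc(C(C)=O)c(O)cc1OCCCCC#N`: 31% in an assay on isolated protein for inhibition of leukotriene B4 receptor 1 (Homo sapiens), tested at 10 uM; a lower number here means less inhibition, a higher number more inhibition at the concentration tested (going by the name of the read-out)
compound 2, `CCc1cc(C(C)=O)c(O)cc1OCCCCCCC#N`: 103% in this assay

Compound 1 stands lowest of the two numbers; compound 2 sits far higher, beyond the scatter, but differs from compound 1 in more than one place, so no single step can be read from that pair.

Compound 3, `C=CCc1cc(C(C)=O)c(O)cc1OCCCCC#N`, is not yet measured. It differs from compound 1 in one place: vinyl in place of butyl on a saturated chain carbon bound to an aromatic carbon. Within the data shown here, no measured step shows the effect of this change. A modest upward move is expected, a number 11 percentage points higher from compound 1 to compound 3 (beyond the scatter), though a step within the scatter would not surprise. Compound 3 is estimated at 42%, with a range from 12% to 75%.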

Compound 3, a percentage reported as inhibition, at one concentration (the size of the read-out at that concentration, not a potency): 92%
Compound 3: the middle estimate sits 50 percentage points below what was measured; the whole stated range lies below it.
By their numbers in this assay, from the lowest: compound 1; then compound 3; then compound 2.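

In this assay, with the nitrile-linked ether held constant, pentyl to allyl on a saturated chain carbon bound to an aromatic carbon gives a number 61 percentage points higher from compound 1 to compound 3 (beyond the scatter). Among these compounds, this is the first single-place reading, and it shows that this position strongly affects the read-out. No evidence on hand explains the step.

The compounds shown leave open whether the double bond or the smaller carbon count carries the step, a question a saturated propyl group at this place would address. From the compounds shown here alone, how a carboxylic acid in place of the nitrile would read also remains open.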